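Acyl Swap on a Trimethoxyphenyl Benzylamide Pair

The compounds below may be only part of what the source reports. "The series", "measured", "known", "first", "only" and "open" are said of these compounds alone.

Measured compounds:
compound 1, `C/C=C/C(=O)N(Cc1cccc(O)c1)c1cc(OC)c(OC)c(OC)c1`, 6700 nM
compound 2, `CCCCC(=O)N(Cc1ccc(OC)c(O)c1)c1cc(OC)c(OC)c(OC)c1`, 170 nM

In a functional assay on HCT-116 cells (Homo sapiens) for inhibition, read by MTT assay, with a stated time of 48 h (a higher number here means a weaker inhibitor, a lower number a stronger inhibitor), compound 2 gives 170 nM, the lowest of the two numbers shown; compound 1 gives 6700 nM, a gap well beyond the usual scatter. Compound 1 and compound 2 differ in two places at once, so the two values alone do not say which change carries the gap.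

Compound 3, `C/C=C/C(=O)N(Cc1ccc(OC)c(O)c1)c1cc(OC)c(OC)c(OC)c1`, keeps the benzyl part of compound 2 and changes only the acyl group: prop-1-en-1-yl in place of butyl on a carbonyl carbon. It thereby shares its acyl group with compound 1. Going by the values given here, no pair differing in this one place has been measured, so the size of the step is open. Compound 3 is expected to lose some potency relative to compound 2, since compound 1, which carries the same acyl group, gives 6700 nM; the step is estimated as a 2.9-fold higher number from compound 2 to compound 3 (0.47 log units; beyond the scatter). Compound 3 is therefore expected at 500 nM, within 120 nM to 2500 nM.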

Compound 3, half-maximal inhibitory concentration: 55 nM
Compound 3: the middle estimate sits 9.1-fold (0.96 log units) above what was measured; measured number outside the range, below it.
By their numbers in this assay, from the lowest: compound 3; then compound 2; then compound 1.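

With the acyl group held as prop-1-en-1-yl, the benzyl part can now be read on its own in this assay: methoxy in place of hydrogen on an aromatic carbon brings a large gain (a 120-fold lower number from compound 1 to compound 3 (2.09 log units; beyond the scatter)), the largest single step among these compounds. The acyl change on the carbonyl carbon, prop-1-en-1-yl in place of butyl, gives a modest gain in the same direction (a 3.1-fold lower number from compound 2 to compound 3 (0.49 log units; beyond the scatter)), so the prop-1-en-1-yl group does not carry the weak value of compound 1, and the butyl group is not needed for a low number. No measurement offered here explains either step.

Going by these compounds, it remains open whether the methoxy step keeps its size when the acyl group is butyl. On these data alone, how a longer chain such as hexyl, or an acyl group bearing an amine, would behave on this carbonyl carbon also remains open.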